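Adding One Hydroxy to Compound 2

The source may report more compounds than this note shows. Statements on the series, on what has been measured and on what is new or still open speak of the compounds shown alone.

Going by the values given here, only two compounds have numbers so far in a functional assay on MCF7 cells (Homo sapiens) for inhibition, read by MTT assay, with a stated time of 48 h (on this read-out lower numbers stand for stronger inhibition and higher numbers for weaker inhibition), and they sit well apart. Compound 1 (`COc1ccc(-c2nnnn2-c2cc(OC)c(OC)c(OC)c2)c(O)c1O`) gives 6600 nM in this test, while compound 2 (`COc1ccc(-c2nnnn2-c2cc(OC)c(OC)c(OC)c2O)cc1`) gives 72000 nM and so holds the higher, weaker number of the pair, by a gap beyond the usual scatter.

Compound 3 (`COc1ccc(-c2nnnn2-c2cc(OC)c(OC)c(OC)c2O)c(O)c1`) is compound 2 with a single change: hydroxy in place of hydrogen on an aromatic carbon, which turns 4-methoxyphenyl into 2-hydroxy-4-methoxyphenyl (hydroxy in place of hydrogen on an aromatic carbon). The new group sits ortho to a large group and meta to a methoxy group.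

Among the compounds with values here, no measured pair isolates this change, since the two tested compounds differ in more than one place. Within the data shown here, the one hint is compound 1 at 6600 nM. Compound 1 also carries hydroxy on the ring that changes, so a move toward a lower number seems more likely than none. The expected change is a moderate fall, estimated as a 3.6-fold lower number from compound 2 to compound 3 (0.56 log units; beyond the scatter) and only loosely known. For compound 3 the expected value in this assay is 20000 nM (estimated range 6000 nM to 70000 nM).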

Compound 3, half-maximal inhibitory concentration: 46000 nM
Estimate against measurement, compound 3: 2.3-fold (0.36 log units) below; low and high end bracket the measured number.
By their numbers in this assay, from the lowest: compound 1; then compounds 3 and 2 (each within the scatter of the next).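

Read directly for the first time, hydroxy in place of hydrogen on this aromatic carbon gives a 1.6-fold lower number from compound 2 to compound 3 (0.19 log units; within the scatter) in this assay, so the two numbers cannot be told apart. At this place, ortho to a large group and meta to a methoxy group, the new hydroxy therefore shows no effect that this test can separate from ordinary repeat variation. The 2-hydroxy-4-methoxyphenyl group is thus accepted without a loss beyond the scatter, but a single hydroxy here does not bring a clear gain either. Nothing available explains why this step stays so small.

The compounds shown leave open whether a different group on this same carbon, such as an amine, a fluorine atom or a carboxylic acid, would move the number beyond the scatter. They also leave open whether the same hydroxy would give a similarly small step on a compound that differs elsewhere in its structure, since this single pair describes only one setting.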